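Cyclopropyl for Methyl on a Sulfonyl Sulfur

This account rests on a few compounds, and the source may have more. Where it says the series, first, only, none or still open, it means among the compounds named here.

In an ADME assay on microsomes from liver (Homo sapiens) for metabolic stability (a higher number here means faster removal of the compound, a lower number slower removal), compound 1 `CC(C)n1cnc2c(-c3ccc(F)c(Oc4ccc(C#N)cn4)c3)cnnc21` gives 38 mL.min-1.g-1 and compound 2 `CCn1cnc2c(-c3ccc(F)c(-c4cc(C#N)ccc4OC)c3)cnnc21` gives 66 mL.min-1.g-1, two values within the usual scatter of each other. Compound 3 `CCn1cnc2c(-c3ccc(F)c(-c4ccc(S(C)(=O)=O)cc4OC)c3)cnnc21` gives < 8 mL.min-1.g-1, which is a limit of the assay and not a number. It alone of the three stands at a limit, so its true position is not known.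

Compound 4 `CCn1cnc2c(-c3ccc(F)c(-c4ccc(S(=O)(=O)C5CC5)cc4OC)c3)cnnc21` differs from compound 3 by one change: cyclopropyl in place of methyl on a sulfonyl sulfur. No measured pair among these compounds shows this change, so the expectation is a loose one. A small upward step in this assay is expected, possibly no larger than the scatter. The estimated step is an at least 1.3-fold higher number from compound 3 to compound 4 (0.13 log units; that floor lies within the scatter), and it is uncertain because it starts from compound 3 at < 8 mL.min-1.g-1, a limit. A reading for compound 4 at the same limit would remain quite possible. For compound 4 the expected value is 11 mL.min-1.g-1, with an estimated range from 6 mL.min-1.g-1 to 24 mL.min-1.g-1.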

Compound 4, intrinsic clearance in microsomes in the Homo sapiens assay: < 12 mL.min-1.g-1
Compound 4 gave a limit, no number; the forecaster's own chance of this, stated with the estimate: 40%; the middle value is on the limit's open side.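

In the Homo sapiens assay compound 3 gives < 8 mL.min-1.g-1 as a limit of the assay and not a number. In the Homo sapiens assay compound 4 gives < 12 mL.min-1.g-1 as a limit of the assay and not a number. Among these compounds, in the Homo sapiens assay no step between compound 3 and compound 4 can be read. The compounds shown leave open where the true values of compound 3 and compound 4 lie, and whether cyclopropyl in place of methyl on a sulfonyl sulfur changes the read-out at all. In a physicochemical assay for lipophilicity (on this read-out higher numbers stand for higher lipophilicity and lower numbers for lower lipophilicity), compound 3 gives 2.5 and compound 4 gives 2.7 as two values within the usual scatter of each other.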